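The compounds below may be only part of what the source reports. "The series", "measured", "known", "first", "only" and "open" are said of these compounds alone.

In an ADME assay on Huh-7 cells (Homo sapiens) for cytotoxicity, with a stated time of 3 days (a lower number here means that less compound is tolerated, a higher number that more compound is tolerated), compound 1 `COc1ccccc1NC(=O)c1c(NO)cc(-c2ccccc2)oc1=O` gives only a limit of the assay, > 20000 nM. Compound 2 `COc1cccc(NC(=O)c2c(NO)cc(-c3ccccc3)oc2=O)c1` likewise gives only a limit in this assay, > 20000 nM. The step that the two limits leave unreadable from compound 1 to compound 2 comes with the change (3-methoxyphenyl in place of 2-methoxyphenyl on an amide-type nitrogen). Compound 3 `COc1ccccc1NC(=O)c1c(NCCO)cc(-c2ccc(Br)cc2)oc1=O` also sits at a limit in this assay, > 20000 nM. How the core of compound 3 differs from the core of compound 1 is not broken down here. Compound 4 `COc1cccc(NC(=O)c2c(NCCO)cc(-c3ccc(Br)cc3)oc2=O)c1` is reached from compound 3 by the same change, (3-methoxyphenyl in place of 2-methoxyphenyl on an amide-type nitrogen). Within the data shown here, because of the limit of > 20000 nM in this assay, at which 3 of the 3 values shown sit, no measured step has a readable size. The step that the limit leaves unreadable from compound 3 to compound 4 is therefore expected to be small. Compound 4 is expected, on this basis, to give about 30000 nM in this assay, within a range from 15000 nM to 100000 nM, most likely again only as a limit.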

Compound 4, half-maximal cytotoxic concentration: > 20000 nM
Compound 4 was reported as a limit; the forecaster's own chance of this, stated with the estimate: 85%; the middle value lies beyond the limit too.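

In this assay the size of the step from compound 3 to compound 4 cannot be read: the limit of > 20000 nM in this assay, at which 4 of the 4 values shown sit. The compounds shown leave open at what concentration any of them harms these cells, and whether 3-methoxyphenyl and 2-methoxyphenyl differ there.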